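Bromo-to-iodo exchange on the exocyclic carbon of compound 1

The compounds below may be only part of what the source reports. "The series", "measured", "known", "first", "only" and "open" are said of these compounds alone.

Compound 1 `CCC[C@@H](OC(C)=O)C1=C(Br)/C(=C/Br)OC1=O` is the acetoxy member of the set. In a functional assay on Lu1 cells (Homo sapiens) for cytotoxicity (a lower number here means that less compound is needed, a higher number that more compound is needed for the effect), compound 1 gives 1.7 ug/mL, the highest of the two numbers measured in the series. Compound 3 `CCC[C@@H](O)C1=C(Br)/C(=C/Br)OC1=O` carries hydroxy where compound 1 carries acetoxy, and in this assay compound 3 gives 0.3 ug/mL; the step is a 5.7-fold lower number from compound 1 to compound 3 (0.75 log units; beyond the scatter). Compound 2 `CCCCC1=C(Br)/C(=C/Br)OC1=O` has hydrogen in place of the chain oxygen substituent, and in this assay compound 2 reaches only > 20 ug/mL, which is a limit of the assay rather than a number. Compound 2 sits at the limit of > 20 ug/mL in this assay, at which 1 of the 3 values shown sits. The steps of an at least 11-fold higher number from compound 1 to compound 2 (1.07 log units; beyond the scatter) and an at least 66-fold lower number from compound 2 to compound 3 (1.82 log units; beyond the scatter) show that the oxygen substituent on the chain governs the activity seen so far.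

Compound 4 `CCC[C@@H](OC(C)=O)C1=C(Br)/C(=C/I)OC1=O` differs from compound 1 in a single place: iodo in place of bromo on a double-bonded chain carbon bound to a double-bonded ring carbon. None of the three measured steps touches the halogens on the core; all of them concern the chain substituent. Within the data shown here, no measured step therefore bears directly on this change, and no movement beyond the scatter is expected from it. For compound 4 the estimate in this assay is 1.7 ug/mL, with a range from 0.7 ug/mL to 4.5 ug/mL, which would mean no change at the digits printed from compound 1 to compound 4 (within the scatter).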

Compound 4, concentration for half-maximal effect: 1.5 ug/mL
The estimate for compound 4 lay 1.1-fold (0.05 log units) above the measured number, within the range that was stated.
By their numbers in this assay, from the lowest: compound 3; then compounds 4 and 1 (each within the scatter of the next). At a limit, above all of these: compound 2.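

In this assay, iodo in place of bromo on a double-bonded chain carbon bound to a double-bonded ring carbon gives a 1.1-fold lower number from compound 1 to compound 4 (0.05 log units; within the scatter), so this position accepts the exchange, with acetoxy on the chain, without a movement beyond the scatter. Among these compounds, the earlier steps all concerned the chain substituent, and this is the first reading on a halogen of the shared core: here the identity of the halogen, bromo or iodo, makes no difference that can be told apart in this cytotoxicity read-out, whereas the steps on the chain oxygen substituent all lie beyond the scatter. Nothing in the data shown explains why the exchange leaves the number in place.

The compounds shown leave open whether iodo at this place behaves the same way with hydroxy on the chain, as in compound 3, or with the plain butyl chain of compound 2. They also leave open what a group other than a halogen at this place, such as a nitrile or a methyl, would do, and what iodo would do in place of the bromo on the ring.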